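Dipropylamino in place of ethyl(methyl)amino: working notes

The compounds below may be only part of what the source reports. "The series", "measured", "known", "first", "only" and "open" are said of these compounds alone.

In a functional assay on MCF7 cells (Homo sapiens) for antiproliferative activity (on this read-out higher numbers stand for weaker inhibition and lower numbers for stronger inhibition), compound 1 `CC(C)=CCc1cc(C(=O)Nc2cc3ccc(OCC4CCN(C)C4)c(C)c3oc2=O)ccc1O` gives 1550 nM while compound 2 `CC(C)=CCc1cc(C(=O)Nc2cc3ccc(OCCCN4CCCC4)c(C)c3oc2=O)ccc1O` gives 990 nM and compound 3 `CCN(C)CCCOc1ccc2cc(NC(=O)c3ccc(O)c(CC=C(C)C)c3)c(=O)oc2c1C` gives 2190 nM on the same read-out. Two steps fix where the last stands: a 1.4-fold higher number from compound 1 to compound 3 (0.15 log units; within the scatter) and a 2.2-fold higher number from compound 2 to compound 3 (0.34 log units; beyond the scatter) in this assay.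

Compound 4 `CCCN(CCC)CCCOc1ccc2cc(NC(=O)c3ccc(O)c(CC=C(C)C)c3)c(=O)oc2c1C` differs from it at the amine: dipropylamino in place of ethyl(methyl)amino on a saturated chain carbon, three bonds along the chain from an oxygen on an aromatic ring. This is dipropylamino in place of ethyl(methyl)amino on a saturated chain carbon. Among the measured compounds shown here, the closest precedent is the amine swap at that place, a 2.2-fold higher number from compound 2 to compound 3 (0.34 log units; beyond the scatter), and it is modest. For the measured compounds named here, no measured compound carries dipropylamino, so direction stays open. The expected step is a 1.4-fold lower number from compound 3 to compound 4 (0.14 log units; within the scatter) and none beyond the scatter is anticipated. Compound 4 is estimated at 1600 nM with a range of 700 nM to 3500 nM here.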

Compound 4, half-maximal inhibitory concentration: > 50000 nM
Compound 4: a limit, no number; the forecaster's own chance of this, stated with the estimate: 3%; middle value at least 31-fold (1.49 log units) away from the limit.
By their numbers in this assay, from the lowest: compounds 2, 1 and 3 (each within the scatter of the next, the first and the last beyond it). At a limit, above all of these: compound 4.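

Among the compounds shown here, the amine end of this chain proves far less forgiving than the earlier compounds suggested: the largest earlier change was a 2.2-fold higher number from compound 2 to compound 3 (0.34 log units; beyond the scatter), whereas dipropylamino in place of ethyl(methyl)amino gives an at least 22-fold higher number from compound 3 to compound 4 (1.35 log units; beyond the scatter). The gap is as wide against the other two amines, with an at least 50-fold higher number from compound 2 to compound 4 (1.70 log units; beyond the scatter) and an at least 32-fold higher number from compound 1 to compound 4 (1.50 log units; beyond the scatter). In this assay compound 4 gives a limit and not a number: the limit of > 50000 nM in this assay, at which 1 of the 4 values shown sits.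

A diethylamino or piperidin-1-yl group at this place would show whether the loss sets in short of dipropylamino. On these data alone, the true size of these steps stays open.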